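Amide variation at the ring methyl position of compound 1

This account rests on a few compounds, and the source may have more. Where it says the series, first, only, none or still open, it means among the compounds named here.

Compound 1 `CCCCNc1nc(N)nc2cccc(C)c12` carries a methyl on its aromatic core, and in an ADME assay on HEK293 cells for agonist activity at Toll-like receptor 8 (Homo sapiens), read by a luciferase reporter, with a stated time of 6 h (on this read-out lower numbers stand for an effect already at smaller amounts and higher numbers for an effect only at larger amounts of compound), compound 1 gives 0.3 uM. Compound 2 `CCCCNc1nc(N)nc2cccc(C(=O)N(C)C(C)C)c12` replaces that methyl with an isopropyl(methyl)carbamoyl group; in this assay compound 2 reaches only the limit > 25 uM, which is a boundary of the measurement rather than a number. The step of an at least 83-fold higher number from compound 1 to compound 2 (1.92 log units; beyond the scatter) therefore places compound 2 at the weak end of what has been measured, as the limit of > 25 uM in this assay, at which 1 of the 2 values shown sits, shows. Compound 3 `CCCCNc1nc(N)nc2cccc(C(=O)N[C@@H](C)c3ccccc3)c12` is not yet measured and differs from compound 2 by (1-phenylethyl)amino in place of isopropyl(methyl)amino on a carbonyl carbon. Among the compounds with values here, only the single step from compound 1 to compound 2 bears on this change, and it concerns the entry of the amide rather than its amine part, so no measured step speaks directly to compound 3. Compound 3 is expected to stay near the weak end, with the step of an at least 1.6-fold lower number from compound 2 to compound 3 (0.22 log units; that floor lies within the scatter). The estimate for compound 3 is 15 uM, within 3 uM to 50 uM.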

Compound 3, minimum effective concentration: > 25 uM
Compound 3 gave a limit, no number; the forecaster's own chance of this, stated with the estimate: 45%; at least 1.6-fold (0.22 log units) between middle value and limit.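

Compound 2 and compound 3 each give only a limit in this assay and no number, so the step between them cannot be read. The compounds shown leave open whether any amide in place of the methyl of compound 1 gives a readable value.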